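The source may report more compounds than this note shows. Statements on the series, on what has been measured and on what is new or still open speak of the compounds shown alone.

In a functional assay on HeLa cells (Homo sapiens) for cytotoxicity, read by MTT assay, with a stated time of 72 h (on this read-out lower numbers stand for stronger inhibition and higher numbers for weaker inhibition), compound 1 `CC(C)(C)C1=CC(=O)C=C(NCCC(=O)O)C1=O` gives 47100 nM and compound 2 `CC(C)C[C@H](NC1=CC(=O)C=C(C(C)(C)C)C1=O)C(=O)O` gives 57200 nM. These two values lie within the usual scatter of each other, so compound 2 stands level with compound 1. Compound 3 `C[C@H](NC1=CC(=O)C=C(C(C)(C)C)C1=O)C(=O)O` differs from compound 2 by one change: hydrogen in place of isopropyl on a saturated chain carbon, two bonds along the chain from an amine nitrogen and a carbonyl carbon, with hydrogen in place of isopropyl on a saturated chain carbon, two bonds along the chain from an amine nitrogen and a carbonyl carbon. Among the compounds with values here, no measured pair shows this change on its own. The expected step in this assay is therefore none beyond the scatter, an estimated 1.0-fold lower number from compound 2 to compound 3 (0.02 log units; within the scatter). For compound 3 the estimated value is 55000 nM, with an expected range of 28000 nM to 110000 nM.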

Compound 3, half-maximal inhibitory concentration: 89100 nM
For compound 3 the middle estimate is 1.6-fold (0.21 log units) below the measured one; low and high end bracket the measured number.
By their numbers in this assay, from the lowest: compounds 1, 2 and 3 (each within the scatter of the next).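

In this assay, within the data shown here, hydrogen in place of isopropyl on this saturated chain carbon gives a 1.6-fold higher number from compound 2 to compound 3 (0.19 log units; within the scatter), so the first measured change at this position, isobutyl to methyl, stays within the scatter. Compound 3 also carries 1-carboxyethyl in place of the 2-carboxyethyl of compound 1 on the amine nitrogen, and this gives a 1.9-fold higher number from compound 1 to compound 3 (0.28 log units; within the scatter), likewise within the scatter. No measured evidence here accounts for either step. Still open, on these data alone, is how a benzyl group on that chain carbon would read, or a methyl ester in place of the carboxylic acid.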